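The source may report more compounds than this note shows. Statements on the series, on what has been measured and on what is new or still open speak of the compounds shown alone.

Measured in a functional assay on HCT-116 cells (Homo sapiens) for inhibition, read by sulforhodamine B assay, with a stated time of 48 h, tested at 50 uM; on this read-out lower numbers stand for less inhibition of growth and higher numbers for more inhibition of growth at the one concentration tested:
- compound 1 `COc1ccc2c(c1)C(=O)C(=O)N2CCCCCn1cc(COc2cc(=O)oc3ccccc23)nn1`: 25%
- compound 2 `O=C1C(=O)N(CCCCCn2cc(COc3cc(=O)oc4ccccc34)nn2)c2ccc(Br)cc21`: 43%
- compound 3 `O=C1C(=O)N(CCCCCn2cc(COc3cc(=O)oc4ccccc34)nn2)c2ccccc21`: 65%

Compound 3 stands highest of the three numbers, beyond the scatter against both others: the step of a number 22 percentage points higher from compound 2 to compound 3 (beyond the scatter) is modest, the step of a number 40 percentage points higher from compound 1 to compound 3 (beyond the scatter) is large. The two substituted compounds also differ from each other, the step of a number 18 percentage points higher from compound 1 to compound 2 (beyond the scatter) being modest, so on these three numbers the substituent on that aromatic carbon matters, and the unsubstituted compound 3 sits at the top.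

Compound 4 `O=C1C(=O)N(CCCCCn2cc(COc3cc(=O)oc4ccccc34)nn2)c2ccc(I)cc21` differs from compound 3 by iodo in place of hydrogen on an aromatic carbon. Among the compounds with values here, the step that bears on this most directly is the one from compound 2 to compound 3, where removing the bromo from the same aromatic carbon gave a number 22 percentage points higher from compound 2 to compound 3 (beyond the scatter); compound 4 puts an iodo group back onto that carbon, a change of the same kind in the opposite direction. The step from compound 1 to compound 3 points the same way, any group at that carbon so far lowering the number. A modest decrease in this assay is therefore expected, a number 23 percentage points lower from compound 3 to compound 4 (beyond the scatter), with the bromo analogue compound 2 as the nearest guide. Compound 4 is estimated at 42%, expected between 22% and 62%.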

Compound 4, percent growth inhibition at one concentration: 36%
Compound 4: middle estimate off by 6 percentage points, on the high side; the measured number falls inside the stated range.
By their numbers in this assay, from the lowest: compound 1; then compounds 4 and 2 (each within the scatter of the next); then compound 3.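

In this assay, the step of a number 29 percentage points lower from compound 3 to compound 4 (beyond the scatter) adds iodo as a third group on this aromatic carbon that gives a lower number than hydrogen, so within these four compounds the unsubstituted compound 3 stays on top of methoxy, bromo and iodo alike. The exchange of one halogen for the other adds no separate effect, as the step of a number 7 percentage points lower from compound 2 to compound 4 (within the scatter) leaves bromo and iodo unresolved at this carbon in this single-concentration read-out. The step of a number 11 percentage points higher from compound 1 to compound 4 (beyond the scatter) shows that the identity of the group still matters, since iodo parts from methoxy here and compound 1 remains the lowest of the set.

Open, as far as these compounds go, is whether a fluoro group, an amine or a carboxylic acid on this same aromatic carbon would also fall short of compound 3, and whether the order seen here would hold with a shorter or longer chain joining the two halves of the molecule. Nothing at hand gives a reason for any of these steps, so they stand as observed differences only.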